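Three Analogues at the Cytotoxicity Limit, and a Fourth

The source may hold more compounds than are shown below. What is called first, only, known or untested is meant among the compounds shown, and "the series" means these compounds.

The measured compounds and their values:
compound 1 `CCCCNc1nc(N)nc2c1ncn2/C=C1/CC1(CO)CO`: > 300000 nM
compound 2 `Nc1nc(OCC(F)(F)F)c2ncn(/C=C3/CC3(CO)CO)c2n1`: > 300000 nM
compound 3 `Nc1nc2c(ncn2/C=C2/CC2(CO)CO)c(=O)[nH]1`: > 300000 nM

In an ADME assay on HFF cells (Homo sapiens) for cytotoxicity, with a stated time of 8 days (on this read-out lower numbers stand for higher toxicity in this test and higher numbers for lower toxicity in this test), compound 2 reaches only a limit of the assay, not a number. The same holds for compound 1, and for compound 3 in this assay as well. Of the three values shown, every one sits at the same limit (the limit of > 300000 nM in this assay, at which 3 of the 3 values shown sit), so compound 2 cannot be placed higher or lower than either of its neighbours. Going by the values given here, the only measured step touching it, a step that the two limits leave unreadable from compound 1 to compound 2, is unreadable for the same reason.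

Compound 4 `CC(C)Nc1nc(N)nc2c1ncn2/C=C1/CC1(CO)CO` differs from compound 2 in one place: isopropylamino in place of 2,2,2-trifluoroethoxy on an aromatic carbon. Among the compounds with values here, no measured step in this assay bears on this change with a readable size, so no step beyond the scatter is expected in either direction. Compound 4 is therefore estimated to remain at the limit of this assay, at about 400000 nM (range 200000 nM to 1500000 nM), which means an expected step that the limit leaves unreadable from compound 2 to compound 4.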

Compound 4, half-maximal cytotoxic concentration: > 300000 nM
Compound 4 ended at the assay's limit; the forecaster's own chance of this, stated with the estimate: 85%; the middle value is on the limit's open side.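

In this assay neither new step, from compound 1 to compound 4 or from compound 2 to compound 4, can be read, because every value is a limit: the limit of > 300000 nM in this assay, at which 4 of the 4 values shown sit. The compounds shown leave open how the four rank against one another and which change on the shared core would bring a value off that limit.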